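Swapping the core substituent: a small expected shift

This account rests on a few compounds, and the source may have more. Where it says the series, first, only, none or still open, it means among the compounds named here.

The measure at hand is a physicochemical assay for acid dissociation. Of the compounds shown here, three have been measured. Compound 1 `COc1ccccc1Oc1ccc2c(NCCCNCc3ccco3)ccnc2c1` gives 9.28. Compound 2 `COc1ccc(F)cc1CNCCCNc1ccnc2cc(CCC(C)C)ccc12` gives 9.47. Compound 3 `COc1ccc(F)cc1CNCCCNc1ccnc2cc(Cc3cc(C)cc(C)c3)ccc12` gives 9.47, level with compound 2 at the digits shown, and together these two are the highest of the three; compound 1 lies a little lower, but that gap is within the scatter, so no real order among the three can be claimed.

For the measured compounds named here, the only single-point step among the measured compounds is no change at the digits printed from compound 2 to compound 3 (within the scatter). Replacing one saturated-carbon-linked group on the core with another left the reading unchanged.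

Compound 4 `COc1ccc(F)cc1CNCCCNc1ccnc2cc(Oc3ccccc3OC)ccc12` is the next to be measured. It differs from compound 3 in one place: 2-methoxyphenoxy in place of 3,5-dimethylbenzyl on an aromatic carbon. Compound 1 carries the same 2-methoxyphenoxy group on its core, with a different group on the amine, and its value sits within the scatter of compound 3. Going by the values given here, since the one step that changes the core substituent moved nothing, the expected step of a number 0.12 log units lower from compound 3 to compound 4 (within the scatter) is small, if anything slightly downward. The expected value for compound 4 in this assay is 9.35, within a range from 9 to 9.7.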

Compound 4, acid dissociation constant: 9.28
Compound 4: the middle estimate sits 0.07 log units above what was measured, within the range that was stated.
By their numbers in this assay, from the lowest: compounds 1, 4, 2 and 3 (each within the scatter of the next).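

In this assay the change to 2-methoxyphenoxy on the aromatic carbon of the shared core gives a number 0.19 log units lower from compound 3 to compound 4 (within the scatter) and a number 0.19 log units lower from compound 2 to compound 4 (within the scatter) and so, with both steps inside the scatter, this position has now held a phenoxy group as well as the two carbon-linked groups without any real shift in the reading. For the compounds shown here, the amine end of the molecule can also be read on its own for the first time, since 5-fluoro-2-methoxyphenyl in place of furan-2-yl gives no change at the digits printed from compound 1 to compound 4 (within the scatter) and leaves the reading just as steady for a change at the far end of the chain. Nothing available here bears on why the reading holds steady across these changes.

The compounds shown do not tell which atom gives up the proton behind this reading. They also leave open whether a group of a different kind at this position, such as an amine or a carboxylic acid, would move the reading beyond the scatter, as all three groups seen there so far leave it within.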